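Trading methyl for tert-butyl on a carbonyl carbon

The compounds below may be only part of what the source reports. "The series", "measured", "known", "first", "only" and "open" are said of these compounds alone.

Within the data shown here, in a physicochemical assay for solubility, read by HPLC, in phosphate buffer, measured as kinetic solubility, at pH 7.4 (a lower number here means a less soluble compound, a higher number a more soluble compound), two compounds built on a shared core have numbers so far. Compound 1 (`CCCC(=O)c1cc(-c2ccc(S(N)(=O)=O)cc2)n(-c2ccc(Cl)cc2)n1`) gives 25800 nM there, while compound 2 (`CC(=O)c1cc(-c2ccc(S(N)(=O)=O)cc2)n(-c2ccc(Cl)cc2)n1`) gives 86800 nM as the higher of the two.

Compound 3 (`CC(C)(C)C(=O)c1cc(-c2ccc(S(N)(=O)=O)cc2)n(-c2ccc(Cl)cc2)n1`) has not been measured. It carries tert-butyl in place of methyl on a carbonyl carbon and is otherwise the same as compound 2.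

Among the measured compounds shown here, only one measured step bears on this change. It is a 3.4-fold higher number from compound 1 to compound 2 (0.53 log units; beyond the scatter) when hydrogen replaces ethyl on a saturated chain carbon bound to a carbonyl carbon. That step is modest but beyond the scatter. Read backwards, it pairs the larger carbon group with the lower number. Tert-butyl is not the chain of compound 1, however, and one step is thin evidence, so the comparison is only a rough guide.

The expectation is therefore a 3.9-fold lower number from compound 2 to compound 3 (0.60 log units; beyond the scatter) in this assay as a step of similar size in the downward direction. For compound 3 the estimated value is 22000 nM with an expected range from 7000 nM to 65000 nM on this measure.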

Compound 3, solubility: 6600 nM
For compound 3 the middle estimate is 3.3-fold (0.52 log units) above the measured one; measured number below the stated range.
By their numbers in this assay, from the lowest: compound 3; then compound 1; then compound 2.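

In this assay, tert-butyl in place of methyl on this carbonyl carbon gives a 13-fold lower number from compound 2 to compound 3 (1.12 log units; beyond the scatter), so a change at this one position can produce a large step, not only the modest one seen earlier. Tert-butyl also falls clearly short of the propyl of compound 1, with a 3.9-fold lower number from compound 1 to compound 3 (0.59 log units; beyond the scatter), which means the three groups now run in a single order from the highest number to the lowest: methyl, propyl, tert-butyl, with none of the three compounds going against it. The data shown offer no measured explanation for these differences.

Still open, as far as these compounds go, is whether the order tracks the size of the group or its branched shape, a question that a straight butyl chain on the same carbonyl carbon could help to settle. Also open, from the compounds shown here alone, is how an amine or a carboxylic acid at this position would read in this assay, and whether the same steps would appear on a different core.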